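This account rests on a few compounds, and the source may have more. Where it says the series, first, only, none or still open, it means among the compounds named here.

Measured so far in a functional assay on the whole organism for antagonist activity, with Mus musculus as the target; on this read-out higher numbers stand for an effect only at larger amounts of compound and lower numbers for an effect already at smaller amounts
- compound 1 `Cn1c(-c2ccccc2)nnc1S(C)(=O)=O` gives > 200 mg/kg (a limit)
- compound 2 `Cc1ccc(-c2nnc([S+](C)[O-])n2C)cc1` gives > 200 mg/kg (a limit)

Compound 2 stands at > 200 mg/kg, a limit and not a number. Compound 3 `Cc1ccc(-c2nnc(S(C)(=O)=O)n2C)cc1` differs from compound 2 on an aromatic carbon, where methylsulfonyl enters: a group of 4 heavy atoms (1 carbon, 2 oxygen, 1 sulfur; no ring) in place of a group of 3 heavy atoms (1 carbon, 1 oxygen, 1 sulfur; no ring), on an aromatic carbon. Compound 1 already carries methylsulfonyl, and its > 200 mg/kg is likewise a limit. From that, the expected change in this assay is small and toward smaller doses: an at least 1.3-fold lower number from compound 2 to compound 3 (0.12 log units; that floor lies within the scatter). A further reading at the limit is also expected to be quite possible. For compound 3 the estimate is 150 mg/kg, with an expected range of 50 mg/kg to 300 mg/kg.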

Compound 3, dose for half-maximal effect: > 200 mg/kg
Compound 3: only a limit was reported (the forecaster's own chance of this, stated with the estimate: 55%); middle value at least 1.3-fold (0.12 log units) from the limit.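

No step can be read from compound 1 or compound 2 to compound 3 in this assay, since each reading is a limit and not a number: the limit of > 200 mg/kg in this assay, at which 3 of the 3 values shown sit.

The compounds shown leave open whether any change on the shared core gives a measurable dose in this assay.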